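The source may hold more compounds than are shown below. What is called first, only, known or untested is meant among the compounds shown, and "the series" means these compounds.

Compound 1 `O=C(O)CC1COc2cc(OCc3ncc(-c4ccccc4)s3)ccc21`: 5.26%
Compound 2 `O=C(O)CC1COc2cc(OCc3csc(-c4ccccc4)n3)ccc21`: 0.15%
Compound 3 `Cc1ccccc1-c1nc(C)c(COc2ccc3c(c2)OCC3CC(=O)O)s1`: 10.7%

These three compounds carry the same shared core and were all run in a functional assay on CHO cells for agonist activity at Free fatty acid receptor 1 (Homo sapiens), read by FLIPR and calcium flux, tested at 100 nM; on this read-out lower numbers stand for a weaker effect and higher numbers for a stronger effect at the one concentration tested. For the measured compounds named here, on the numbers so far, compound 3 has the highest value of the three. Its nearest neighbour is compound 1, whose value lies lower by an amount that stays within the usual scatter of repeated measurements, so the two cannot be told apart. Compound 2 sits furthest away, lower by an amount beyond the scatter. All three values are small, so none of the compounds gives more than a weak effect at the single concentration tested.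

Compound 4 `Cc1nc(-c2ccc(F)cc2)sc1COc1ccc2c(c1)OCC2CC(=O)O` has not yet been measured in this assay. It differs from compound 3 in one place: 4-fluorophenyl in place of 2-methylphenyl on an aromatic carbon. The exchange sits on an aromatic carbon of a five-membered aromatic ring with 1 nitrogen and 1 sulfur.

No step between measured compounds that differ in a single place is available, so this exchange has no direct precedent among the compounds shown. The three measured values are all low and spread over a narrow band. The change is therefore expected to be small, a number 2.7 percentage points lower from compound 3 to compound 4 (within the scatter), with no direction beyond the scatter. Compound 4 is expected to give about 8% in this assay, within a range from 1% to 25%.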

Compound 4, a percentage reported as activity, at one concentration (the size of the read-out at that concentration, not a potency): 61.6%
Beside the measured number, compound 4's estimate is 53.6 percentage points below it; the measured number lies above the stated range.
By their numbers in this assay, from the lowest: compounds 2, 1 and 3 (each within the scatter of the next, the first and the last beyond it); then compound 4.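

Exchanging 2-methylphenyl for 4-fluorophenyl on this aromatic carbon of the five-membered ring gives a number 50.9 percentage points higher from compound 3 to compound 4 (beyond the scatter) in this assay, so the group held here can decide whether a compound on this core gives a weak or a clear effect at the one concentration tested. The two groups have the same count of heavy atoms, one six-membered aromatic ring of carbon only, no hydrogen-bond donors or acceptors and no net charge, so those counts do not separate them; what differs is which substituent the phenyl ring carries and where it carries it. Nothing among the data given explains why this exchange has so large an effect.

This single step removes a methyl and adds a fluorine at once, so it cannot say which of the two matters, and a chlorine atom or a methoxy group in place of the fluorine would help to show how specific the gain is to fluorine. From the compounds shown here alone, the read-out also gives the size of the effect at one concentration, so how potent compound 4 is stays open.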